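The source may report more compounds than this note shows. Statements on the series, on what has been measured and on what is new or still open speak of the compounds shown alone.

compound 1 `COc1ccc(O)c(C(=O)OC/C=C(C)/C=C/C=C(C)/C=C/C2=CCCCC2(C)C)c1` gives 570000 nM
compound 2 `COc1cc(O)c(C(=O)OC/C=C(C)/C=C/C=C(C)/C=C/C2=CCCCC2(C)C)c(O)c1` gives 14000 nM
compound 3 `CC(/C=C/C1=CCCCC1(C)C)=C\C=C\C(C)=C\COC(=O)c1ccc(O)cc1O` gives 120000 nM

These three esters share one core and differ only in the aromatic group on the carbonyl carbon. In a toxicity assay on cells (Fibroblast, Homo sapiens) for cytotoxicity (a lower number here means a stronger inhibitor, a higher number a weaker inhibitor), compound 3, at 120000 nM, holds the middle place, with a lower number than compound 1 and a higher number than compound 2.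

Compound 4 `COc1cccc(O)c1C(=O)OC/C=C(C)/C=C/C=C(C)/C=C/C1=CCCCC1(C)C` keeps the shared core and carries 2-hydroxy-6-methoxyphenyl in place of 2,4-dihydroxyphenyl on a carbonyl carbon. Among the compounds with values here, no measured step makes exactly this swap, so the evidence is indirect. Compound 1 and compound 2 both carry a methoxy group, which compound 3 lacks, yet they fall on opposite sides of it. The modest step of a 4.8-fold lower number from compound 1 to compound 3 (0.68 log units; beyond the scatter) points to a higher number for compound 4, while the modest step of an 8.6-fold higher number from compound 2 to compound 3 (0.93 log units; beyond the scatter) points to a lower one. The large step of a 41-fold lower number from compound 1 to compound 2 (1.61 log units; beyond the scatter) shows how far apart two methoxy-bearing compounds can lie. The data therefore give no firm direction in this assay, and only a slight lean towards compound 1, which shares the count of hydroxy and methoxy groups with compound 4.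

The expected change is small, an estimated 1.3-fold higher number from compound 3 to compound 4 (0.10 log units; within the scatter).

For compound 4 the estimate is 150000 nM, with an expected range from 30000 nM to 600000 nM.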

Compound 4, half-maximal inhibitory concentration: 230000 nM
For compound 4 the middle estimate is 1.5-fold (0.19 log units) below the measured one; the measured number falls inside the stated range.
By their numbers in this assay, from the lowest: compound 2; then compounds 3 and 4 (each within the scatter of the next); then compound 1.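

In this assay, putting 2-hydroxy-6-methoxyphenyl in place of 2,4-dihydroxyphenyl on this carbonyl carbon gives a 1.9-fold higher number from compound 3 to compound 4 (0.28 log units; within the scatter) and so shows that this swap, which trades one of the hydroxy groups for a methoxy group, leaves the number within the usual scatter. The comparison with compound 1 is sharper, since 2-hydroxy-5-methoxyphenyl and 2-hydroxy-6-methoxyphenyl differ only in where the methoxy group stands on the ring, and a 2.5-fold lower number from compound 1 to compound 4 (0.39 log units; beyond the scatter) is a step beyond the scatter, so the place of that group matters here and not just its presence. The group of compound 2 stays apart from this new one as well, with a 16-fold higher number from compound 2 to compound 4 (1.22 log units; beyond the scatter) as a large step, so carrying a methoxy group does not by itself bring a compound close to compound 2.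

The compounds shown leave open how a ring carrying an amine or a carboxylic acid in place of the hydroxy group would fall in this assay and whether a longer chain than methoxy would shift the number further. Nothing measured here explains these differences.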